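Working notes: isopropyl on the aromatic nitrogen

The source may report more compounds than this note shows. Statements on the series, on what has been measured and on what is new or still open speak of the compounds shown alone.

Compound 1 `CCOC(=O)c1ccc(-c2nn(Cc3cccnc3)c3ccccc23)cc1`: > 10000 nM (a limit)
Compound 2 `CCOC(=O)c1ccc(-c2nn(-c3ccco3)c3ccccc23)cc1`: > 10000 nM (a limit)

In a functional assay on cells (Platelet, Homo sapiens) for inhibition (a higher number here means a weaker inhibitor, a lower number a stronger inhibitor), compound 2 stands only at a limit, > 10000 nM. Compound 3 `CCOC(=O)c1ccc(-c2nn(C(C)C)c3ccccc23)cc1` has isopropyl in place of furan-2-yl on an aromatic nitrogen. Going by the values given here, the one measured step bearing on this, a step that the two limits leave unreadable from compound 1 to compound 2, has no readable size, and the evidence amounts to the limit of > 10000 nM in this assay, at which 2 of the 2 values shown sit. No size or direction carries over from it, so no clear gain is expected, and a further limit is the likeliest result. The estimated step is a step that the limit leaves unreadable from compound 2 to compound 3. For compound 3 the expected value is 15000 nM, with an estimated range of 4000 nM to 50000 nM.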

Compound 3, half-maximal inhibitory concentration: > 10000 nM
Compound 3: a limit, no number; the forecaster's own chance of this, stated with the estimate: 75%; the middle value lies beyond the limit too.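

Going by these compounds alone, compound 1, compound 2 and compound 3 each stand only at a limit in this assay, so no step among them can be read. The compounds shown leave open whether any group on the aromatic nitrogen gives a measurable inhibition value.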